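The source may hold more compounds than are shown below. What is called first, only, known or untested is meant among the compounds shown, and "the series" means these compounds.

Measured compounds:
compound 1, `C=C(Br)C(=O)Nc1ccc2c(c1)/C(=C/c1cccs1)C(=O)N2`, 1700 nM
compound 2, `C=C(Br)C(=O)Nc1ccc2c(c1)/C(=C\c1cccs1)C(=O)N2`, 2300 nM
compound 3, `C=C(Br)C(=O)Nc1ccc2c(c1)CC(=O)N2`, 3300 nM

These three compounds were tested in a functional assay on MCF7 cells (Homo sapiens) for antiproliferative activity, read by MTT assay, with a stated time of 72 h; a lower number here means a stronger inhibitor, a higher number a weaker inhibitor. Compound 1 gives the lowest of the three numbers, but its gaps to compound 2 and to compound 3 are both within the scatter, so none of the three can be set apart from the others. Among the compounds with values here, the only step between two compounds that differ in one place is the one from compound 1 to compound 2, a 1.4-fold higher number from compound 1 to compound 2 (0.13 log units; within the scatter), and compound 3 sits no further from compound 1 than that.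

Compound 4, `C=C(Br)C(=O)Nc1ccc2c(c1)/C(=C/c1sccc1C)C(=O)N2`, has not yet been measured in this assay. It differs from compound 1 by methyl in place of hydrogen on an aromatic carbon. Within the data shown here, no measured step touches that change: the step from compound 1 to compound 2 concerns only the configuration as drawn (the fact that compounds 1 and 2 differ only in the configuration as drawn), and the shift from compound 1 to compound 3 is also within the scatter. Among the measured compounds shown here, nothing among the measured compounds speaks to a methyl on the ring. For the measured compounds named here, because the one measured step of a 1.4-fold higher number from compound 1 to compound 2 (0.13 log units; within the scatter) stayed within the scatter, compound 4 is expected to land near compound 1, with the step of no change at the digits printed from compound 1 to compound 4 (within the scatter) estimated to stay within the scatter. For compound 4 the estimate in this assay is 1700 nM, ranging from 800 nM to 3600 nM.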

Compound 4, half-maximal inhibitory concentration: 2600 nM
The estimate for compound 4 lay 1.5-fold (0.18 log units) below the measured number; the measured number falls inside the stated range.
By their numbers in this assay, from the lowest: compounds 1, 2, 4 and 3 (each within the scatter of the next).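

In this assay, the change from thiophen-2-yl to 3-methylthiophen-2-yl, which places a methyl on an aromatic carbon next to the ring atom that bears a large group, gives a 1.5-fold higher number from compound 1 to compound 4 (0.18 log units; within the scatter) and so stays within the scatter. Within the data shown here, this is the first reading of a change on the five-membered ring itself, as the only earlier step between compounds differing in one place concerned the configuration as drawn, and it shows that this position carries a methyl with no shift that can be told apart from repeat measurement. None of the information available explains why this change leaves the number within the scatter.

With a methyl as the only group shown at this position, the compounds leave open whether an ethyl, a methoxy, a chlorine or an amine would also stay within the scatter of compound 1. They also leave open whether a methyl on another carbon of that ring, or the same methyl on the opposite double-bond configuration of compound 2, would do the same.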